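The compounds below may be only part of what the source reports. "The series", "measured", "known", "first", "only" and "open" are said of these compounds alone.

Compound 1, `Cc1noc(Cn2nc3ccc(-c4ccc(Oc5ccc(F)cc5)cc4)cn3c2=O)n1`, is one of two compounds that have been run through an ADME assay on microsomes (Rattus norvegicus) for metabolic stability (a lower number here means that the compound disappears faster, a higher number that the compound lasts longer), so far. In this assay compound 1 gives 1.42 h, the lower of the two numbers recorded. Going by the values given here, the other compound, compound 2, `Cc1nc(Cn2nc3ccc(-c4ccc(OC(F)(F)F)cc4)cn3c2=O)no1`, gives 6.05 h in this assay, a higher number that lies beyond the usual scatter; no single-point step connects compound 2 to compound 1, so the two values stand on their own.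

The next compound to be measured is compound 3, `O=c1n(Cc2noc(CO)n2)nc2ccc(-c3ccc(Oc4ccc(F)cc4)cc3)cn12`. It differs from compound 1 in one place: 5-(hydroxymethyl)-1,2,4-oxadiazol-3-yl in place of 3-methyl-1,2,4-oxadiazol-5-yl on a saturated chain carbon bound to an aromatic nitrogen. Among the compounds with values here, nothing in the measured pair speaks to a change of this kind, so there is no step to lean on. The expected step in this assay, a 1.2-fold lower number from compound 1 to compound 3 (0.07 log units; within the scatter), is therefore small, without a clear direction, and not beyond the scatter. Compound 3 is expected to give about 1.2 h in this assay, within a range from 0.5 h to 3 h, with the measured number yet to come.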

Compound 3, half-life: 0.533 h
Beside the measured number, compound 3's estimate is 2.3-fold (0.35 log units) above it, and the stated range covers the measured number.
By their numbers in this assay, from the lowest: compound 3; then compound 1; then compound 2.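

At this position, on a saturated chain carbon bound to an aromatic nitrogen, the attached group does matter in this assay: 5-(hydroxymethyl)-1,2,4-oxadiazol-3-yl in place of 3-methyl-1,2,4-oxadiazol-5-yl gives a 2.7-fold lower number from compound 1 to compound 3 (0.43 log units; beyond the scatter), a modest step beyond the scatter and the only one so far that can be read between compounds differing in one place. This single change covers two differences at once, since the ring is attached the other way round and the group that enters carries a hydroxymethyl with 1 hydrogen-bond donor, whereas the group that leaves carries a methyl with 0. No measured evidence bears on why the number falls with this change.

Which of these two differences carries the step remains open, as does the question of whether a methoxymethyl or an aminomethyl group on the same ring would give a number like that of compound 3. On these data alone, it is also open whether the same step would appear on the other side of the molecule, with the aryl group of compound 2 in place of that of compound 1.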